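This account rests on a few compounds, and the source may have more. Where it says the series, first, only, none or still open, it means among the compounds named here.

Measured so far:
compound 1 `CC(C)COc1ncc(-c2cn(C)c3cc(C(=O)NS(C)(=O)=O)ccc23)cc1Cl` — 95%
compound 2 `CC(C)COc1ncc(-c2cn(C)c3cc(C(=O)NS(C)(=O)=O)c(F)cc23)cc1Cl` — 100%
compound 3 `Cn1cc(-c2ccc(C(F)(F)F)cc2)c2cc(F)c(C(=O)NS(C)(=O)=O)cc21` — 97%

All three numbers come from an ADME assay on microsomes from liver (Homo sapiens) for metabolic stability, with a stated time of 10 min, tested at 0.5 uM (a higher number here means that more of the compound is left, a lower number that less of the compound is left), and lie within the usual scatter of one another. The difference between the core of compound 2 and the core of compound 3 is not broken down here. Compound 2 and compound 1 differ by a single change, (hydrogen in place of fluoro on an aromatic carbon), which gives a number 5 percentage points lower from compound 2 to compound 1 (within the scatter). Compound 4 `Cn1cc(-c2ccc(C(F)(F)F)cc2)c2ccc(C(=O)NS(C)(=O)=O)cc21` is not yet measured; it differs from compound 3 by hydrogen in place of fluoro on an aromatic carbon, the same change, at a place described in the same words. Resting on a number 5 percentage points lower from compound 2 to compound 1 (within the scatter), a step of similarly small size is expected for compound 4: a number 3 percentage points lower from compound 3 to compound 4 (within the scatter). Compound 4 is therefore expected to give about 94% in this assay, with a range from 85% to 100%.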

Compound 4, percent of the compound remaining: 100%
The estimate for compound 4 lay 6 percentage points below the measured number; the range from low to high includes it.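

In this assay, hydrogen in place of fluoro on an aromatic carbon gives a number 3 percentage points higher from compound 3 to compound 4 (within the scatter). Set beside the earlier step, the two cores cannot be told apart for this change: the same change on two cores in this assay, a number 5 percentage points lower (within the scatter) from compound 2 to compound 1 and a number 3 percentage points higher (within the scatter) from compound 3 to compound 4, 8 percentage points apart, within the scatter of two such steps. This shows no core dependence that stands clear of the scatter, but it does not show that the steps on the two cores are equal, that the change has no effect, or how it would read on a further core.

Only fluoro and hydrogen appear at this place on the aromatic ring. As far as these compounds go, a nitrile or a methoxy group there remains open, as does a carboxylic acid in place of the (methylsulfonyl)carbamoyl group.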